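A pyridinylmethyl sulfonyl group replaces isopropyl in compound 2

This account rests on a few compounds, and the source may have more. Where it says the series, first, only, none or still open, it means among the compounds named here.

Of the compounds shown here, two have been tested in an assay on isolated protein for inhibition of matrix metalloproteinase-9 (Homo sapiens); on this read-out higher numbers stand for weaker inhibition and lower numbers for stronger inhibition. Compound 1, `Cc1ccc(Oc2ccc(N(CC(=O)NO)S(C)(=O)=O)cc2)cc1`, gives 31 nM. Compound 2, `Cc1ccc(Oc2ccc(N(C[C@H](O)C(=O)NO)S(=O)(=O)C(C)C)cc2)cc1`, gives 286 nM, the higher of the two numbers, and compound 2 therefore stands as the weaker inhibitor of the pair, with a gap to compound 1 that is beyond the scatter. Among the measured compounds shown here, since these two compounds differ in more than one place, their values show only that the pair spans a wide range; no single cause can be read from them.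

Compound 3, `Cc1ccc(Oc2ccc(N(C[C@H](O)C(=O)NO)S(=O)(=O)Cc3cccnc3)cc2)cc1`, is not yet measured. It differs from compound 2 by (pyridin-3-yl)methyl in place of isopropyl on a sulfonyl sulfur. For the measured compounds named here, no measured pair separates this change on its own, so there is no step to lean on. The change is expected to move the number only a little in this assay, with a 1.6-fold lower number from compound 2 to compound 3 (0.20 log units; within the scatter) toward slightly stronger inhibition but not clearly beyond the scatter. Compound 3 is therefore estimated at 180 nM in this assay, within a range from 50 nM to 650 nM.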

Compound 3, half-maximal inhibitory concentration: 69 nM
Estimate against measurement, compound 3: 2.6-fold (0.42 log units) above, and the stated range covers the measured number.
By their numbers in this assay, from the lowest: compound 1; then compound 3; then compound 2.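

On the sulfonyl sulfur, whose other neighbour is the sulfonamide nitrogen, putting (pyridin-3-yl)methyl in place of isopropyl gives a 4.1-fold lower number from compound 2 to compound 3 (0.62 log units; beyond the scatter) in this assay. This is the first pair shown that differs in one place only, so it shows that inhibition responds to the group at this position and that a larger group carrying an aromatic ring is compatible with stronger inhibition. Nothing available explains why the number falls.

This single step cannot say whether the ring, its nitrogen or the linking carbon matters; a benzyl group, which has the ring without the nitrogen, would help to separate these. From the compounds shown here alone, compound 1 differs from compound 3 in more than one place, so the separate contributions of the sulfonyl substituent and the hydroxyl group on the chain remain open.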